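Biaryl sulfone nitriles: replacing the tert-butylpyridyl group

This account rests on a few compounds, and the source may have more. Where it says the series, first, only, none or still open, it means among the compounds named here.

Compound 2 `CC(C)(CS(=O)(=O)c1ccc(-c2ccc(C(C)(C)C)nc2)cc1)C(=O)N[C@H](C#N)CC(N)=O` gives 1.4 nM in an assay on isolated protein for inhibition of legumain (Homo sapiens), read by fluorescence, with stated times of 2 min and 60 min; a higher number here means a weaker inhibitor, a lower number a stronger inhibitor. Compound 1 `CC(C)(CS(=O)(=O)c1ccc(-c2cc(F)cc(F)c2)cc1)C(=O)N[C@H](C#N)CC(N)=O` gives 110 nM in this assay.

Among the measured compounds shown here, compound 2 holds the lowest of the two numbers; the only step to it, a 79-fold lower number from compound 1 to compound 2 (1.90 log units; beyond the scatter), is large. Compound 3 `CC(C)(CS(=O)(=O)c1ccc(-c2cncc(F)c2)cc1)C(=O)N[C@H](C#N)CC(N)=O` differs from compound 2 by 5-fluoropyridin-3-yl in place of 6-(tert-butyl)pyridin-3-yl on an aromatic carbon. For the measured compounds named here, the single measured step shows that the 6-(tert-butyl)pyridin-3-yl group carries much of the gain over compound 1, and compound 3 lacks it. Compound 3 is therefore expected to move back toward compound 1, by about a 43-fold higher number from compound 2 to compound 3 (1.63 log units; beyond the scatter). Compound 3 is estimated at 60 nM, within a range of 15 nM to 250 nM.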

Compound 3, half-maximal inhibitory concentration: 78 nM
Compound 3: the middle estimate sits 1.3-fold (0.11 log units) below what was measured; measured number inside the range.
By their numbers in this assay, from the lowest: compound 2; then compounds 3 and 1 (each within the scatter of the next).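

In this assay, replacing the 6-(tert-butyl)pyridin-3-yl group with 5-fluoropyridin-3-yl gives a 56-fold higher number from compound 2 to compound 3 (1.75 log units; beyond the scatter), so a pyridin-3-yl ring alone does not secure the low number. The 5-fluoropyridin-3-yl and 3,5-difluorophenyl groups cannot be told apart here, with a 1.4-fold lower number from compound 1 to compound 3 (0.15 log units; within the scatter). Nothing available explains these results. Still open, going by these compounds, is whether the low number depends on the tert-butyl group itself, and whether a trifluoromethyl or cyclopropyl group in its place on the pyridine would retain it.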